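Bicyclic amines: heteroaryl swap and tolerated concentration

This account rests on a few compounds, and the source may have more. Where it says the series, first, only, none or still open, it means among the compounds named here.

Measured so far:
compound 1, `C[C@H]1[C@H](NCc2cncs2)C[C@H]2C[C@@H]1C2(C)C`: > 100000 nM
compound 2, `CCCCc1ccsc1CN[C@@H]1C[C@H]2C[C@@H]([C@H]1C)C2(C)C`: 25000 nM

In an ADME assay on MDCK cells (Canis lupus familiaris) for cytotoxicity, read by microscopy, with a stated time of 48 h (a higher number here means that more compound is tolerated, a lower number that less compound is tolerated), compound 1 gives > 100000 nM, which is a limit of the assay and not a number. Compound 2 gives 25000 nM in this assay. Compound 1 therefore stands at the tolerated edge of what this assay can report (the limit of > 100000 nM in this assay, at which 1 of the 2 values shown sits), while compound 2 sits at a measured number. For the measured compounds named here, the two measured compounds differ in more than one place, so no single step between them can be drawn; only their two values are set side by side here.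

Compound 3 `C[C@H]1[C@H](NCc2ccco2)C[C@H]2C[C@@H]1C2(C)C` has not yet been measured in this assay. Its difference from compound 1 is the following: furan-2-yl in place of 1,3-thiazol-5-yl on a saturated chain carbon bound to an amine nitrogen. Going by the values given here, no measured pair covers this particular exchange, so the expectation rests on compound 1 alone, whose value is a limit. The step of a number no higher from compound 1 to compound 3 (the limit leaves the size open) is expected to stay within the usual scatter, with no set direction. Compound 3 is accordingly estimated at 100000 nM, with a range from 30000 nM to 300000 nM.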

Compound 3, minimum cytotoxic concentration: 50000 nM
Compound 3: the middle estimate sits 2.0-fold (0.30 log units) above what was measured, and the stated range covers the measured number.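

Compound 3 gives 50000 nM in this assay, so with furan-2-yl in place of 1,3-thiazol-5-yl on a saturated chain carbon bound to an amine nitrogen, the read-out at this place on the core of compound 1 becomes a number rather than a limit. Compound 1 gives > 100000 nM, which is a limit of the assay and not a number: the limit of > 100000 nM in this assay, at which 1 of the 3 values shown sits. The exchange therefore reads only as an at least 2.0-fold lower number from compound 1 to compound 3 (0.30 log units; that floor lies within the scatter), so this floor alone does not separate the two five-membered aromatic rings, and the full size of the step stays unfixed.

Open is whether the true step from the thiazolyl to the furanyl compound lies beyond the usual scatter, which the compounds shown cannot settle while one side of the pair is a limit. Also open, from the compounds shown here alone, is whether a phenyl or a pyridin-3-yl group on the same chain carbon, with the core of compound 1 unchanged, would give a number like that of compound 3 or a limit like that of compound 1.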